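A Longer Chain on a Shared Core

The source may hold more compounds than are shown below. What is called first, only, known or untested is meant among the compounds shown, and "the series" means these compounds.

In a functional assay, read by spectrophotometry, with a stated time of 6 min (a lower number here means a stronger inhibitor, a higher number a weaker inhibitor), compound 1 `CCCCOc1cc(OC)ccc1C(C)=O` gives 36300000 nM and compound 2 `CCCCCCCCOc1cc(OC)ccc1C(C)=O` gives 38300000 nM. These two values lie within the scatter of each other, so compound 2 stands level with compound 1 and neither can be ranked above the other.

Compound 3 `CCCCCCCCCCCCCCCCOc1cc(OC)ccc1C(C)=O` differs from compound 2 by one change: octyl in place of hydrogen on a saturated chain carbon, eight bonds along the chain from an oxygen on an aromatic ring. In words, this is octyl in place of hydrogen on a saturated chain carbon, eight bonds along the chain from an oxygen on an aromatic ring.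

Going by the values given here, only one measured step bears on this change. It is a 1.1-fold higher number from compound 1 to compound 2 (0.02 log units; within the scatter), which came from butyl in place of hydrogen on a saturated chain carbon, four bonds along the chain from an oxygen on an aromatic ring. That step stayed within the scatter, so no clear shift in either direction is expected in this assay this time.

The estimated change is a 1.0-fold lower number from compound 2 to compound 3 (0.00 log units; within the scatter), which would again be no more than scatter. Among the compounds with values here, no measured compound carries a chain this long, and one step is thin evidence, so the range is kept wide. For compound 3 the expected value is 38000000 nM, within an estimated range of 16000000 nM to 85000000 nM.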

Compound 3, half-maximal inhibitory concentration: 36300000 nM
Beside the measured number, compound 3's estimate is 1.0-fold (0.02 log units) above it; the range from low to high includes it.
By their numbers in this assay, from the lowest: compounds 1, 3 and 2 (each within the scatter of the next).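

In this assay the new step reads (a 1.1-fold lower number from compound 2 to compound 3 (0.02 log units; within the scatter)), so compound 2 and compound 3 stand level even with octyl added on a saturated chain carbon, eight bonds along the chain from an oxygen on an aromatic ring. Read with the earlier step (a 1.1-fold higher number from compound 1 to compound 2 (0.02 log units; within the scatter)), this places all three compounds within the scatter of one another, so the butyl chain of compound 1, the octyl chain of compound 2 and the still longer chain of compound 3 cannot be ranked. The first pair covered only a single addition, whereas this series now shows no measurable difference across a much greater range of chain lengths, and no measurement shown offers a reason for that.

As far as these compounds go, all three compounds carry a plain saturated chain at this oxygen, so it remains open how the assay would read a chain ending in an amine or a carboxylic acid, or one carrying a phenyl ring. From the compounds shown here alone, whether a chain shorter than butyl, such as ethyl, would stand level with these three also remains open.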